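This account rests on a few compounds, and the source may have more. Where it says the series, first, only, none or still open, it means among the compounds named here.

Working notes on the series. Compound 1 `Cc1ccc(NC(=O)COc2nc3ccccc3nc2C)cc1` and compound 2 `Cc1nc2ccccc2nc1OCC(=O)Nc1ccc(Cl)cc1` are built on one core; compound 3 `Cc1ccc(C(=O)Nc2ccc(Cn3c(=O)c(C)nc4ccccc43)cc2)cc1` and compound 4 `Cc1nc2ccccc2n(Cc2ccc(NC(=O)c3ccc(Cl)cc3)cc2)c1=O` are built on another. The difference between the two cores is not broken down here. In a functional assay on cells (Homo sapiens) for inhibition, read by MTT assay, with a stated time of 24 h (a higher number here means a weaker inhibitor, a lower number a stronger inhibitor), compound 1 gives only a limit of the assay, > 100000 nM. Compound 2 likewise gives only a limit in this assay, > 100000 nM. Compound 3 too gives only a limit in this assay, > 100000 nM.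

The change from compound 1 to compound 2 is chloro in place of methyl on an aromatic carbon. Its step, a step that the two limits leave unreadable from compound 1 to compound 2, cannot be read, because both ends rest on (the limit of > 100000 nM in this assay, at which 3 of the 3 values shown sit). The change from compound 3 to compound 4 is chloro in place of methyl on an aromatic carbon, the same change in the same kind of place. For the measured compounds named here, with every value so far sitting on (the limit of > 100000 nM in this assay, at which 3 of the 3 values shown sit), the step from compound 3 to compound 4 is expected to be flat, a number no higher from compound 3 to compound 4 (the limit leaves the size open). Compound 4 is therefore expected to give 100000 nM in this assay, between 30000 nM and 300000 nM, most likely again only as a limit.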

Compound 4, half-maximal inhibitory concentration: > 100000 nM
Compound 4 gave a limit, no number (the forecaster's own chance of this, stated with the estimate: 85%); the middle value lies on the limit itself.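

Compound 4 also gives only a limit in this assay, > 100000 nM. No new step can be read from compound 3 to compound 4, because both ends rest on a limit: the limit of > 100000 nM in this assay, at which 4 of the 4 values shown sit.

The compounds shown leave open whether chloro in place of methyl changes inhibition on either core, and whether the two cores differ at all in this assay.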